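This account rests on a few compounds, and the source may have more. Where it says the series, first, only, none or still open, it means among the compounds named here.

Compound 1 `CC1CC(C)CN(c2nc(Nc3ccc(C#N)c(C(F)(F)F)c3)nc(Oc3ccnc4ccccc34)n2)C1`: in a functional assay on DU-145 cells (Homo sapiens) for cytotoxicity, read by sulforhodamine B assay, with a stated time of 48 h (on this read-out higher numbers stand for weaker inhibition of growth and lower numbers for stronger inhibition of growth), compound 1 gives 68000 nM. Compound 2 `N#Cc1ccc(Nc2nc(Oc3ccnc4ccccc34)nc(N3CCC(Cc4ccccc4)CC3)n2)cc1C(F)(F)F`: compound 2 reaches only the limit > 100000 nM in this assay. Compound 3 `N#Cc1ccc(Nc2nc(Oc3ccnc4ccccc34)nc(N3CCN(c4ncccn4)CC3)n2)cc1C(F)(F)F`: compound 3 likewise reaches only the limit > 100000 nM in this assay.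

Compound 3 therefore stands at the limit of this assay, where two of the three values shown sit (the limit of > 100000 nM in this assay, at which 2 of the 3 values shown sit). Going by the values given here, the one measured step that touches it, an at least 1.4-fold higher number from compound 1 to compound 3 (0.16 log units; that floor lies within the scatter), runs from a number up to the limit, and its floor lies within the scatter. Compound 4 `N#Cc1ccc(Nc2nc(Oc3ccnc4ccccc34)nc(N3CCCCC3)n2)cc1C(F)(F)F` differs from compound 3 in one place: piperidin-1-yl in place of 4-(pyrimidin-2-yl)piperazin-1-yl on an aromatic carbon. The entering piperidin-1-yl is closer in kind to the 3,5-dimethylpiperidin-1-yl of compound 1, and compound 1 gave 68000 nM rather than a limit. Since the step from compound 1 to compound 3 may have been nothing at all, no step beyond the scatter is expected in this assay for compound 4 in either direction, though the chance that compound 4 is again reported only as a limit remains considerable. The estimate for compound 4 is 90000 nM with a range from 40000 nM to 200000 nM, which means an expected step of an at least 1.1-fold lower number from compound 3 to compound 4 (0.04 log units; that floor lies within the scatter).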

Compound 4, concentration for total growth inhibition: > 100000 nM
Compound 4 ended at the assay's limit; the forecaster's own chance of this, stated with the estimate: 50%; middle value at least 1.1-fold (0.04 log units) from the limit.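

In this assay, compound 4 is reported only as a limit, which shows that the unsubstituted piperidin-1-yl at this place, opposite the ring nitrogen, ends at the same limit as the benzyl-bearing piperidine of compound 2 and the 4-(pyrimidin-2-yl)piperazin-1-yl of compound 3: the limit of > 100000 nM in this assay, at which 3 of the 4 values shown sit. Among the four compounds, only the 3,5-dimethylpiperidin-1-yl of compound 1 gives a number rather than a limit, yet the change to piperidin-1-yl amounts to an at least 1.4-fold higher number from compound 1 to compound 4 (0.16 log units; that floor lies within the scatter), so the data do not show that losing the two methyl groups has any real effect. The steps that link compound 4 with compound 2 and compound 3 cannot be read, as both ends of each are limits.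

From the compounds shown here alone, how far compound 2, compound 3 and compound 4 lie past the limit stays unknown, so no order can be given among them. Going by these compounds, it also remains open whether another group at this place, such as morpholin-4-yl, a simple dialkylamine or a longer alkyl chain on the piperidine, would move the number beyond the scatter from compound 1.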